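A few compounds are considered here, and "the series" means these few. Any claim that something is new, unique, unknown or untested is made for them only; others in the source may bear on it.

Working notes on the series. Compound 1 `O=C(Nc1cccc(-n2cc(-c3ccncc3)c(-c3cc(O)cc(Cl)c3)n2)c1)Nc1ccc(Cl)c(C(F)(F)F)c1` carries a urea link and in a functional assay on Malme-3M cells (Homo sapiens) for inhibition, read by sulforhodamine B assay, with a stated time of 48 h, tested at 10 uM (a higher number here means a weaker effect of the compound at the concentration tested, a lower number a stronger effect), compound 1 gives -24.9%. Compound 2 `COc1cc(Cl)cc(-c2nn(-c3cccc(NC(=O)Nc4ccc(Cl)c(C(F)(F)F)c4)c3)cc2-c2ccncc2)c1` is its methoxy counterpart, and in this assay compound 2 gives -19.8%. The change between them is methyl in place of hydrogen on an oxygen on an aromatic ring and it made a step of a number 5.1 percentage points higher from compound 1 to compound 2 (within the scatter). Compound 3 `O=C(Nc1cccc(-n2cc(-c3ccncc3)c(-c3cc(O)cc(Cl)c3)n2)c1)c1cc(C(F)(F)F)cc(C(F)(F)F)c1` replaces the urea with an amide bearing two trifluoromethyl groups; in this assay compound 3 gives 61.8%, a higher number than either compound 1 or compound 2. The difference between the core of compound 1 and the core of compound 3 is not broken down here.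

Compound 4 `COc1cc(Cl)cc(-c2nn(-c3cccc(NC(=O)c4cc(C(F)(F)F)cc(C(F)(F)F)c4)c3)cc2-c2ccncc2)c1` is not yet measured. It differs from compound 3 by methyl in place of hydrogen on an oxygen on an aromatic ring, the same change, at the same place, that leads from compound 1 to compound 2. Because that earlier step was a number 5.1 percentage points higher from compound 1 to compound 2 (within the scatter), the step expected here is also small, estimated as a number 3.2 percentage points higher from compound 3 to compound 4 (within the scatter). The value of compound 4 in this assay is therefore estimated at 65%, with the expected range running from 45% to 85%.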

Compound 4, a percentage reported as activity, at one concentration (the size of the read-out at that concentration, not a potency): 104%
Beside the measured number, compound 4's estimate is 39 percentage points below it; measured number outside the range, above it.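

On the amide core of compound 3, the hydroxy to methoxy change in this assay makes a step of a number 42.2 percentage points higher from compound 3 to compound 4 (beyond the scatter). The size of this step does not carry over from one core to the other: the same change on two cores in this assay, a number 5.1 percentage points higher (within the scatter) from compound 1 to compound 2 and a number 42.2 percentage points higher (beyond the scatter) from compound 3 to compound 4, 37.1 percentage points apart, beyond the scatter of two such steps The cores of compound 1 and compound 3 differ in both the link and the substituents on the ring it carries, so these two pairs do not show which of these features goes with the gap between the steps, nor how the change would behave on any further core.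

The compounds shown leave open whether a urea bearing two trifluoromethyl groups, or an amide bearing the chloro and trifluoromethyl pattern of compound 1, would follow the small step or the large one. Also open, on these data alone, is how this assay would respond to a longer chain on that oxygen, such as ethoxy, or to an amine in place of the hydroxy group.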